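This account rests on a few compounds, and the source may have more. Where it says the series, first, only, none or still open, it means among the compounds named here.

Measured in a functional assay on A-375 cells (Homo sapiens) for antiproliferative activity, read by trypan blue exclusion and crystal violet staining, with a stated time of 72 h; a higher number here means a weaker inhibitor, a lower number a stronger inhibitor:
compound 1 `CCCC(=O)NC(c1ccc(C)cc1)c1cc(Cl)c2cccnc2c1O` gives 120 nM
compound 2 `CCCC(=O)NC(c1ccc(Cl)cc1)c1cc(Cl)c2cccnc2c1O` gives 120 nM
compound 3 `CCCC(=O)NC(c1ccccc1)c1cc(Cl)c2cccnc2c1O` gives 130 nM

Compound 3 at 130 nM lies within the scatter of both compound 1 and compound 2, so the three form a single level on these numbers.

Compound 4 `CCCC(=O)NC(c1ccccc1Cl)c1cc(Cl)c2cccnc2c1O` is next. It differs from compound 3 by chloro in place of hydrogen on an aromatic carbon, ortho to a large group, which reads as phenyl to 2-chlorophenyl: chloro in place of hydrogen on an aromatic carbon.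

Within the data shown here, the steps that bear on this are changes on the same ring. Going from chloro to hydrogen gave a 1.1-fold higher number from compound 2 to compound 3 (0.03 log units; within the scatter), and going from methyl to hydrogen gave a 1.1-fold higher number from compound 1 to compound 3 (0.03 log units; within the scatter). Swapping methyl for chloro gave no change at the digits printed from compound 1 to compound 2 (within the scatter). Among the measured compounds shown here, all three changes sit at another place on that ring, and no measured compound carries a group ortho to a large group there, so the range is kept wide. No shift beyond the scatter is expected, and the expected change is no change at the digits printed from compound 3 to compound 4 (within the scatter).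

For compound 4 the estimated value is 130 nM, with an expected range of 60 nM to 300 nM.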

Compound 4, half-maximal inhibitory concentration: 100 nM
Compound 4: the middle estimate sits 1.3-fold (0.11 log units) above what was measured; low and high end bracket the measured number.
By their numbers in this assay, from the lowest: compounds 4, 1, 2 and 3 (each within the scatter of the next).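

Chloro in place of hydrogen on an aromatic carbon, ortho to a large group, gives a 1.3-fold lower number from compound 3 to compound 4 (0.11 log units; within the scatter) in this assay, so this place on the ring, bare in compounds 1, 2 and 3, accepts a chloro with no shift beyond the scatter. 2-Chlorophenyl in place of 4-chlorophenyl gives a 1.2-fold lower number from compound 2 to compound 4 (0.08 log units; within the scatter), and 2-chlorophenyl in place of 4-methylphenyl gives a 1.2-fold lower number from compound 1 to compound 4 (0.08 log units; within the scatter), so the four compounds stand on a single level. Nothing measured here accounts for this flat response.

As far as these compounds go, whether a methoxy, a dimethylamino or a second phenyl at this same place would stay within the scatter remains open. So does whether any change on this ring can move the number at all.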